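Ethoxycarbonyl to carboxy on a compound at the limit

The compounds below may be only part of what the source reports. "The series", "measured", "known", "first", "only" and "open" are said of these compounds alone.

In a functional assay on SGC-7901 cells (Homo sapiens) for antiproliferative activity, read by MTT assay, with a stated time of 72 h (a higher number here means a weaker inhibitor, a lower number a stronger inhibitor), compound 1 (`CCOC(=O)c1cc(-c2cc(OC)c(OC)c(OC)c2)c(-c2ccc(OC)cc2)s1`) gives 9760 nM, and compound 3 (`CCOC(=O)c1cc(-c2cc(OC)c(OC)c(OC)c2)c(-c2ccc(OC)c(O)c2)s1`) gives 1580 nM. Compound 2 (`CCOC(=O)c1cc(-c2cc(OC)c(OC)c(OC)c2)c(-c2cccc(Br)c2)s1`) reads > 100000 nM, which is a limit of the assay and not a number. It is the only one of the three at the limit of > 100000 nM in this assay, at which 1 of the 3 values shown sits.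

Compound 4 (`COc1cc(-c2cc(C(=O)O)sc2-c2cccc(Br)c2)cc(OC)c1OC`) has hydrogen in place of ethyl on an oxygen next to a carbonyl group, so that ethoxycarbonyl becomes carboxy (hydrogen in place of ethyl on an oxygen next to a carbonyl group).

The measured steps all concern the aryl group rather than this change. They are large for an at least 10-fold higher number from compound 1 to compound 2 (1.01 log units; beyond the scatter) and for an at least 63-fold lower number from compound 2 to compound 3 (1.80 log units; beyond the scatter), and modest for a 6.2-fold lower number from compound 1 to compound 3 (0.79 log units; beyond the scatter). All three measured compounds keep the ethoxycarbonyl group, so none of these steps gives a size for the exchange of ethyl for hydrogen. They show only that this assay responds to the aryl group, which compound 4 shares with compound 2. No step beyond the scatter is therefore expected, although this expectation rests on little.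

The expected outcome is a number no higher from compound 2 to compound 4 (the limit leaves the size open). For compound 4 the estimate is 100000 nM, with an expected range from 30000 nM to 200000 nM.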

Compound 4, half-maximal inhibitory concentration: 93400 nM
The estimate for compound 4 lay 1.1-fold (0.03 log units) above the measured number; the range from low to high includes it.
By their numbers in this assay, from the lowest: compound 3; then compound 1; then compound 4. At a limit, above all of these: compound 2.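

In this assay compound 2 reads > 100000 nM, which is a limit of the assay and not a number. Ethoxycarbonyl to carboxy, the only change at this position among the compounds shown, gives an at least 1.0-fold lower number from compound 2 to compound 4 (0.02 log units; that floor lies within the scatter). This is the first reading of any kind for this position, and it shows that the exchange of ethyl for hydrogen on an oxygen next to a carbonyl group, with the 3-bromophenyl group in place, yields a number where the ethyl ester gave none, yet the step has only a floor and its true size stays unknown, with one bound on it: the limit of > 100000 nM in this assay, at which 1 of the 4 values shown sits.

The compounds shown leave open how the same exchange reads with the 4-methoxyphenyl group of compound 1 or the 3-hydroxy-4-methoxyphenyl group of compound 3, where both partners of the pair could carry a number and the step could have a size. They also leave open how this position responds to an amide, a hydroxymethyl group or a longer chain on the oxygen in place of ethyl.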